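A few compounds are considered here, and "the series" means these few. Any claim that something is new, unique, unknown or untested is made for them only; others in the source may bear on it.

Compound 1 `CONc1nc(N)nc2c1ncn2[C@@H]1O[C@H](CO)[C@@H](O)[C@@]1(C)O` in an ADME assay on CCRF-CEM cells (Homo sapiens) for cytotoxicity, read by trypan blue exclusion, with a stated time of 6 days (on this read-out higher numbers stand for lower toxicity in this test and lower numbers for higher toxicity in this test), gives > 100000 nM, a limit of the assay.
Compound 2 `C[C@@]1(O)[C@H](O)[C@@H](CO)O[C@H]1n1cnc2c(NO)nc(N)nc21` in this assay gives > 100000 nM, likewise a limit.

Among the measured compounds shown here, compound 2 thus stands only at a limit, and the one other value shown is a limit as well. For the measured compounds named here, the single measured step, a step that the two limits leave unreadable from compound 1 to compound 2, is unreadable, and the only evidence is the limit of > 100000 nM in this assay, at which 2 of the 2 values shown sit. Compound 3 `C=C(OCC)c1nc(N)nc2c1ncn2[C@@H]1O[C@H](CO)[C@@H](O)[C@@]1(C)O` differs from compound 2 by 1-ethoxyethenyl in place of hydroxyamino on an aromatic carbon. Going by the values given here, no measured step bears on this change, so no size or direction can be read from the data for it. Among the compounds with values here, with every value so far resting at the limit, compound 3 is expected to stay at or near that limit in this assay. The expected step is therefore a step that the limit leaves unreadable from compound 2 to compound 3, within the scatter. Compound 3 is estimated at 150000 nM, in a range from 30000 nM to 700000 nM.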

Compound 3, half-maximal cytotoxic concentration: > 100000 nM
Compound 3 was reported as a limit; the forecaster's own chance of this, stated with the estimate: 75%; the middle value lies beyond the limit too.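

The steps from compound 1 and from compound 2 to compound 3 cannot be read, as the result gives no number to compare: the limit of > 100000 nM in this assay, at which 3 of the 3 values shown sit.

The compounds shown leave open whether any group on this aromatic carbon would give a value inside the range of this assay.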